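This account rests on a few compounds, and the source may have more. Where it says the series, first, only, none or still open, it means among the compounds named here.

Of the compounds shown here, three built on one shared core have been measured in a functional assay on HT-29 cells (Homo sapiens) for cytotoxicity, read by MTT assay, with a stated time of 72 h; on this read-out lower numbers stand for stronger inhibition and higher numbers for weaker inhibition. Compound 1 `COc1cc2c(Oc3ccc(NC(=O)N/N=C/c4ccc(O)cc4)cc3F)ccnc2cc1OCCCN1CCCCC1` carries a 4-hydroxyphenyl group on a carbon with a double bond to nitrogen, and in this assay compound 1 gives 470 nM. Compound 2 `COc1cc2c(Oc3ccc(NC(=O)N/N=C/c4ccncc4)cc3F)ccnc2cc1OCCCN1CCCCC1` has pyridin-4-yl in that place, and compound 2 gives 940 nM. Compound 3 `COc1cc2c(Oc3ccc(NC(=O)N/N=C/c4cccs4)cc3F)ccnc2cc1OCCCN1CCCCC1` has thiophen-2-yl there, and compound 3 gives 770 nM. On the numbers as read, compound 3 stands second highest of the three, yet a 1.2-fold lower number from compound 2 to compound 3 (0.09 log units; within the scatter) and a 1.6-fold higher number from compound 1 to compound 3 (0.21 log units; within the scatter), so the three values sit close together.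

Compound 4 `COc1cc2c(Oc3ccc(NC(=S)N/N=C/c4ccccc4)cc3F)ccnc2cc1OCCCN1CCCCC1` differs from compound 3 by a group of 11 heavy atoms (8 carbon, 2 nitrogen, 1 sulfur; one six-membered aromatic ring of carbon only) in place of a group of 10 heavy atoms (6 carbon, 2 nitrogen, 1 oxygen, 1 sulfur; one five-membered aromatic ring with 1 hetero atom), on a nitrogen on an aromatic ring. The measured steps, a 2.0-fold higher number from compound 1 to compound 2 (0.30 log units; within the scatter), a 1.6-fold higher number from compound 1 to compound 3 (0.21 log units; within the scatter) and a 1.2-fold lower number from compound 2 to compound 3 (0.09 log units; within the scatter), each exchange only the ring on the carbon with the double bond to nitrogen; none of them covers the part of this change in which the oxygen leaves. Because a 2.0-fold higher number from compound 1 to compound 2 (0.30 log units; within the scatter) and the other two ring exchanges all stay within the scatter, the expected step is a 1.1-fold lower number from compound 3 to compound 4 (0.04 log units; within the scatter), with a wider range to allow for the untested part. Compound 4 is therefore estimated at 700 nM, between 250 nM and 2000 nM.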

Compound 4, half-maximal inhibitory concentration: 210 nM
The estimate for compound 4 lay 3.3-fold (0.52 log units) above the measured number; the whole stated range lies above it.
By their numbers in this assay, from the lowest: compound 4; then compounds 1, 3 and 2 (each within the scatter of the next).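

Unlike the ring exchanges among compound 1, compound 2 and compound 3, which all stayed within the scatter, every step to compound 4 goes beyond it: a 3.7-fold lower number from compound 3 to compound 4 (0.56 log units; beyond the scatter), a 4.5-fold lower number from compound 2 to compound 4 (0.65 log units; beyond the scatter) and a 2.2-fold lower number from compound 1 to compound 4 (0.35 log units; beyond the scatter). This shows that changing the group on the nitrogen on an aromatic ring can shift the number beyond the scatter when the oxygen leaves, sulfur takes its place in the carbonyl position and the ring is a six-membered aromatic ring of carbon only. No measurement at hand gives a reason for this shift.

The compounds shown do not separate the share of the sulfur from the share of the ring, which would take the sulfur paired with thiophen-2-yl or pyridin-4-yl. They also leave open how an amine or a carboxylic acid on that ring would read.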